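Swapping a Naphthyl Group for Dimethoxyphenyl in a Sulfonamide Series

A few compounds are considered here, and "the series" means these few. Any claim that something is new, unique, unknown or untested is made for them only; others in the source may bear on it.

Compound 1 `O=S(=O)(NCCCNCc1cccc2ccccc12)c1cc(C(F)(F)F)cc(C(F)(F)F)c1` stands as the lower of the two measured numbers: in a functional assay on HPAC cells (Homo sapiens) for inhibition, read by MTT assay, with a stated time of 72 h (a higher number here means a weaker inhibitor of growth, a lower number a stronger inhibitor of growth), compound 1 gives 2400 nM. Compound 2 `CC(C)(C)c1ccc(CNCCNS(=O)(=O)c2cc(C(F)(F)F)cc(C(F)(F)F)c2)cc1` differs from compound 1 in more than one place, and in this assay compound 2 gives 14000 nM, a higher number and therefore weaker growth inhibition, a gap that lies beyond the usual scatter. Compound 3 `COc1ccc(CNCCCNS(=O)(=O)c2cc(C(F)(F)F)cc(C(F)(F)F)c2)cc1OC` has not yet been measured. It differs from compound 1 in a single place: 3,4-dimethoxyphenyl in place of naphthalen-1-yl on a saturated chain carbon bound to an amine nitrogen. Among the compounds with values here, no measured pair differs in exactly this way, so there is no directly comparable step to lean on. For compound 3 a modest weakening relative to compound 1 is expected, a 2.5-fold higher number from compound 1 to compound 3 (0.40 log units; beyond the scatter), with the estimated value of compound 3 in this assay being 6000 nM, and a likely range from 2500 nM to 15000 nM.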

Compound 3, concentration for 50% growth inhibition: 3500 nM
Beside the measured number, compound 3's estimate is 1.7-fold (0.23 log units) above it; measured number inside the range.
By their numbers in this assay, from the lowest: compounds 1 and 3 (each within the scatter of the next); then compound 2.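

In this assay, putting 3,4-dimethoxyphenyl in place of naphthalen-1-yl on a saturated chain carbon bound to an amine nitrogen gives a 1.5-fold higher number from compound 1 to compound 3 (0.16 log units; within the scatter), so the two compounds cannot be told apart in this growth test. This place in the structure therefore holds either one six-membered aromatic ring with 2 hydrogen-bond acceptors or 2 such rings with 0 acceptors, with no difference beyond the scatter, which compound 2 could not show since it differs from compound 1 in more than one place. No measurement at hand explains why these two groups read alike.

From the compounds shown here alone, it remains open how a plain phenyl group, or a phenyl group carrying a single methoxy group, would read at this place. Going by these compounds, whether the same swap would read alike on a longer chain also remains unknown.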